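The source may hold more compounds than are shown below. What is called first, only, known or untested is meant among the compounds shown, and "the series" means these compounds.

Compound 1 `COc1cc(/C=C/C(=O)C2=C(/C=C/c3ccc(O)c(OC)c3)NC(=O)NC2c2ccc(N(C)C)cc2)ccc1O`: 82.2%
Compound 2 `COc1cc(/C=C/C(=O)C2=C(/C=C/c3ccc(O)c(OC)c3)NC(=O)NC2c2c(Cl)cccc2Cl)ccc1O`: 33%
Compound 3 `COc1cc(/C=C/C(=O)C2=C(/C=C/c3ccc(O)c(OC)c3)NC(=S)NC2c2ccc(N(C)C)cc2)ccc1O`: 72.1%

These three values come from a functional assay, with a stated time of 20 min, tested at 20 uM; on this read-out lower numbers stand for a weaker effect and higher numbers for a stronger effect at the one concentration tested. Compound 1 and compound 2 differ in one place, (2,6-dichlorophenyl in place of 4-(dimethylamino)phenyl on a saturated ring carbon), and that change gave a number 49.2 percentage points lower from compound 1 to compound 2 (beyond the scatter). Compound 3 carries a different core; the difference between its core and that of compound 1 is not broken down here. Compound 4 `COc1cc(/C=C/C(=O)C2=C(/C=C/c3ccc(O)c(OC)c3)NC(=S)NC2c2c(Cl)cccc2Cl)ccc1O` has not yet been measured. It differs from compound 3 by 2,6-dichlorophenyl in place of 4-(dimethylamino)phenyl on a saturated ring carbon, the same change at the same place as between compound 1 and compound 2. Among the measured compounds shown here, a step of similar size is expected in this assay because a number 49.2 percentage points lower from compound 1 to compound 2 (beyond the scatter) was seen for the single earlier example. The expected step is a number 47.1 percentage points lower from compound 3 to compound 4 (beyond the scatter). Compound 4 is therefore estimated at 25%, with a likely range from 10% to 42%.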

Compound 4, a percentage reported as activity, at one concentration (the size of the read-out at that concentration, not a potency): 33.9%
The estimate for compound 4 lay 8.9 percentage points below the measured number; the measured number falls inside the stated range.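

Replacing 4-(dimethylamino)phenyl with 2,6-dichlorophenyl on the saturated ring carbon gave a number 38.2 percentage points lower from compound 3 to compound 4 (beyond the scatter) in this assay, so the fall seen on the core of compound 1 also appears on the core of compound 3. The two falls cannot be told apart in size, and in this pair of cores the change carried over: the same change on two cores in this assay, a number 49.2 percentage points lower (beyond the scatter) from compound 1 to compound 2 and a number 38.2 percentage points lower (beyond the scatter) from compound 3 to compound 4, 11 percentage points apart, within the scatter of two such steps. Among the compounds shown here, this rests on only two pairs read at one concentration, so it shows nothing about potency or about any other core.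

The compounds shown leave open whether the fall follows the loss of the dimethylamino group or the arrival of the chlorines. Also open, on these data alone, is how a plain phenyl, a 4-chlorophenyl or a 4-methoxyphenyl would read at that carbon.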